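The compounds below may be only part of what the source reports. "The series", "measured", "known", "first", "only" and "open" are said of these compounds alone.

Working notes on three measured compounds and one still to be measured. Compound 1 `CCCCCCCCCO[C@@H]1[C@@H](N)[C@@H](OCC(O)CO)O[C@H](CN)[C@H]1OCCCCCCCCC`, compound 2 `CCCCCCCCCO[C@@H]1[C@@H](N)[C@@H](O[C@H]2[C@H](O)[C@@H](OCCCCCCCCC)[C@H](N)C[C@@H]2N)O[C@H](CN)[C@H]1O` and compound 3 `NC[C@H]1O[C@H](O[C@H]2[C@H](O)[C@@H](OCc3ccc4ccccc4c3)[C@H](N)C[C@@H]2N)[C@H](N)[C@@H](OCc2ccc3ccccc3c2)[C@@H]1O` have been run in a toxicity assay on the whole organism (J774 cells) for cytotoxicity, with Mus musculus as the target, read by MTT assay, with a stated time of 24 h, tested at 10 uM; a lower number here means a stronger effect, a higher number a weaker effect of the compound at the concentration tested. In this assay compound 1 gives 89.7%, compound 2 gives 78.4% and compound 3 gives 86%. Compound 1 thus sits at the high end of the three numbers: its gap to compound 3 lies within the usual scatter, its gap to compound 2 lies beyond it. All three numbers are high, so none of the three compounds shows a strong effect at the concentration tested.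

Compound 4 `C=CCO[C@H]1O[C@H](CN)[C@@H](OCCCCCCCCC)[C@H](OCCCCCCCCC)[C@H]1N` is next in line. Relative to compound 1 it carries vinyl in place of 1,2-dihydroxyethyl on a saturated chain carbon bound to an oxygen on a saturated carbon. Among the measured compounds shown here, no step between measured compounds isolates a change of this kind, so the measured numbers give no direct handle on its size. The rest of the core of compound 1 is untouched, and the change is small in what it removes and adds. The step expected in this assay, a number 5.7 percentage points lower from compound 1 to compound 4 (within the scatter), is therefore a small one, most likely within the scatter, with a slight downward lean as the only plausible direction. Compound 4 is estimated at 84%, with a range from 66% to 98%.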

Compound 4, a percentage reported as activity, at one concentration (the size of the read-out at that concentration, not a potency): 91.4%
For compound 4 the middle estimate is 7.4 percentage points below the measured one; low and high end bracket the measured number.
By their numbers in this assay, from the lowest: compounds 2, 3, 1 and 4 (each within the scatter of the next, the first and the last beyond it).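

In this assay the series now has its first step that changes one place only: a number 1.7 percentage points higher from compound 1 to compound 4 (within the scatter) on exchanging 1,2-dihydroxyethyl for vinyl on a saturated chain carbon bound to an oxygen on a saturated carbon. At this position, then, the 2 hydrogen-bond donors and 2 hydrogen-bond acceptors of the leaving group give way to a group with none, and the read-out stays within the scatter at the concentration tested. No measured evidence bears on the reason for this result. On these data alone, whether an amine, a carboxylic acid or a longer chain at this place would leave the read-out equally unmoved remains open. So does whether the same exchange on a different core would give a step of similar size.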